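Removing One Trifluoromethyl from a Urea Side Chain

This account rests on a few compounds, and the source may have more. Where it says the series, first, only, none or still open, it means among the compounds named here.

Compound 2, `O=C(Nc1cccc(-n2cc(-c3ccncc3)c(-c3ccc(Cl)c(O)c3)n2)c1)Nc1cc(C(F)(F)F)cc(C(F)(F)F)c1`: 1020 nM in a functional assay on NCI-H23 cells (Homo sapiens) for inhibition, read by sulforhodamine B assay, with a stated time of 48 h; a higher number here means a weaker inhibitor of growth, a lower number a stronger inhibitor of growth
Compound 3, `COc1cc(-c2nn(-c3cccc(NC(=O)Nc4ccc(Cl)c(C(F)(F)F)c4)c3)cc2-c2ccncc2)ccc1Cl`: 1310 nM
Compound 1, `COc1cc(-c2nn(-c3cccc(NC(=O)c4ccc(Cl)c(C(F)(F)F)c4)c3)cc2-c2ccncc2)ccc1Cl`: 5390 nM

Compound 2 has the lowest number of the three in this assay. Its nearest neighbour is compound 3, whose number is higher by a gap within the scatter, so the two cannot be ordered; compound 1 sits furthest away, beyond the scatter. Compound 4, `O=C(Nc1cccc(-n2cc(-c3ccncc3)c(-c3ccc(Cl)c(O)c3)n2)c1)Nc1cccc(C(F)(F)F)c1`, has not yet been measured. It differs from compound 2 in one place: hydrogen in place of trifluoromethyl on an aromatic carbon.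

Within the data shown here, only one measured step exists in this set, a 4.1-fold lower number from compound 1 to compound 3 (0.61 log units; beyond the scatter), and it concerns the carbonyl linker rather than the trifluoromethyl group, so no measured step bears directly on the change to compound 4. The two trifluoromethyl groups of compound 2 are part of what sets it apart from compound 3 and compound 1, but those compounds differ from it in several places at once, and nothing separates the contribution of one trifluoromethyl group.

Among the measured compounds shown here, with no direct precedent, compound 4 is expected to give a somewhat higher number than compound 2, a step of a 2.0-fold higher number from compound 2 to compound 4 (0.29 log units; within the scatter), though a result within the scatter would not surprise. The estimate for compound 4 in this assay is 2000 nM, within a range of 700 nM to 6000 nM.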

Compound 4, concentration for 50% growth inhibition: 1900 nM
For compound 4 the middle estimate is 1.1-fold (0.02 log units) above the measured one; the measured number falls inside the stated range.
By their numbers in this assay, from the lowest: compounds 2, 3 and 4 (each within the scatter of the next); then compound 1.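

In this assay, among these compounds, the step at this position reads a 1.9-fold higher number from compound 2 to compound 4 (0.27 log units; within the scatter), the first measured step in this set that isolates a single trifluoromethyl group on the urea side chain. It shows that this group, with its 4 heavy atoms, can give way to hydrogen on this aromatic carbon without a difference the assay can resolve, so compound 4 cannot be ordered against compound 2 and this one trifluoromethyl group is not shown to be needed for the growth inhibition read here. Nothing measured on these compounds gives a reason for this result.

Compound 4 still carries one trifluoromethyl group on the same ring, so the compounds shown leave open whether losing that group as well would also stay within the scatter, or whether at least one such group must remain. They also leave open what other groups would do at the carbon that now bears hydrogen, such as a chlorine atom, a methoxy group, an amine or a carboxylic acid, and whether the same replacement would read alike on another cell line.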